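The source may report more compounds than this note shows. Statements on the series, on what has been measured and on what is new or still open speak of the compounds shown alone.

For the measured compounds named here, in a physicochemical assay for solubility (on this read-out higher numbers stand for higher solubility and lower numbers for lower solubility), the three compounds measured so far each give only a limit, not a number. Compound 2 `CNC(=O)c1cc(C(=O)NCCO)n([C@@H](C)c2ccccc2)n1` gives >= 139 ug/mL, which is a limit. As far as these compounds go, compound 3 `CNC(=O)c1cc(C(=O)N[C@H]2CC[C@H](O)CC2)n([C@@H](C)c2ccccc2)n1` gives >= 180 ug/mL, also a limit, so its exact standing is unknown and it cannot be ranked against the other two.

The next compound, compound 4 `CNC(=O)c1cc(C(=O)N[C@H]2CC[C@H](OC)CC2)n([C@@H](C)c2ccccc2)n1`, differs from compound 3 by one small change: methyl in place of hydrogen on an oxygen on a saturated carbon. This puts methyl in place of hydrogen on an oxygen on a saturated carbon, turning 4-hydroxycyclohexyl into 4-methoxycyclohexyl.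

Going by the values given here, three measured steps touch this side of the molecule, but none gives a size: a step that the two limits leave unreadable from compound 1 to compound 2, a step that the two limits leave unreadable from compound 1 to compound 3 and a step that the two limits leave unreadable from compound 2 to compound 3. Among the compounds with values here, the only guide is compound 1 `CCCNC(=O)c1cc(C(=O)NC)nn1[C@@H](C)c1ccccc1`, which has no hydroxy group yet gives the limit >= 132 ug/mL.

The expected result in this assay is therefore no change beyond the usual scatter: an at least 1.0-fold lower number from compound 3 to compound 4 (0.01 log units; that floor lies within the scatter). For compound 4 the estimate is 175 ug/mL, with an expected range from 90 ug/mL to 300 ug/mL.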

Compound 4, solubility: >= 161 ug/mL
Compound 4: a limit, no number; the forecaster's own chance of this, stated with the estimate: 70%; the middle value is on the limit's open side.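

In this assay compound 4 gives >= 161 ug/mL, which is a limit and not a number. Compounds 1, 2 and 3 also give only limits, so no step among these four compounds can be read. The compounds shown leave open whether any of these side-chain changes alters the read-out at all.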